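A Methyl Group Added to Two Related Cores

The source may report more compounds than this note shows. Statements on the series, on what has been measured and on what is new or still open speak of the compounds shown alone.

In a functional assay on HeLa cells (Homo sapiens) for antiproliferative activity, read by MTT assay, with a stated time of 72 h (a higher number here means a weaker inhibitor, a lower number a stronger inhibitor), compound 1 `COc1cc(CC(O)(COCc2ccccc2)COCc2ccccc2)nc(OC)n1` gives only a limit of > 100000 nM. Compound 2 `COc1nc(CC(O)(COCc2ccccc2)COCc2ccccc2)c(C)c(OC)n1` gives 3700 nM in this assay. For the measured compounds named here, the sole change between them is methyl in place of hydrogen on an aromatic carbon, and the step is an at least 27-fold lower number from compound 1 to compound 2 (1.43 log units; beyond the scatter).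

Compound 3 `C[Si](C)(C)CCOCn1c(CC(O)CO)cc(=O)[nH]c1=O` gives only a limit in this assay, namely > 100000 nM. Two of the three values sit at the limit of > 100000 nM in this assay, at which 2 of the 3 values shown sit. How the core of compound 3 differs from the core of compound 1 is not broken down here.

Compound 4 `Cc1c(CC(O)CO)n(COCC[Si](C)(C)C)c(=O)[nH]c1=O` remains unmeasured. It differs from compound 3 by methyl in place of hydrogen on an aromatic carbon, the same kind of change as between compound 1 and compound 2, but the surroundings differ: here the methyl is ortho to a 2,3-dihydroxypropyl group and meta to a group of 8 heavy atoms, whereas in compound 2 it is ortho to a large group, ortho to a methoxy group and para to a methoxy group. For compound 4 a step of an at least 2.5-fold lower number from compound 3 to compound 4 (0.39 log units; beyond the scatter) is expected, resting on an at least 27-fold lower number from compound 1 to compound 2 (1.43 log units; beyond the scatter), with the starting limit leaving it uncertain. Compound 4 is therefore estimated at 40000 nM, between 8000 nM and 200000 nM.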

Compound 4, half-maximal inhibitory concentration: > 100000 nM
Compound 4: a limit, no number; the forecaster's own chance of this, stated with the estimate: 50%; middle value at least 2.5-fold (0.39 log units) from the limit.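

Compound 3 and compound 4 each give only a limit, not a number, so no step between them can be read: the limit of > 100000 nM in this assay, at which 3 of the 4 values shown sit.

What the methyl group does on the core of compound 3 remains open; among the compounds shown, only compound 1 and compound 2 give a readable step.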